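This account rests on a few compounds, and the source may have more. Where it says the series, first, only, none or still open, it means among the compounds named here.

Working notes on the series. Compound 1 `N#Cc1ccc(NC(=O)NCc2cnc3scc(C#Cc4ccsc4)n23)cc1` gives 73.9 nM in an assay on cells for inhibition of Indoleamine 2,3-dioxygenase 1 (Homo sapiens); a higher number here means a weaker inhibitor, a lower number a stronger inhibitor. Compound 2 `N#Cc1ccc(NC(=O)NCc2cnc3scc(C#CC4CC4)n23)cc1` gives 102 nM in this assay, the higher of the two numbers but within the scatter of compound 1; the step of a 1.4-fold higher number from compound 1 to compound 2 (0.14 log units; within the scatter) is the only measured one. Compound 3 `O=C(NCc1cnc2scc(C#CC3CC3)n12)Nc1cccc(Cl)c1` differs from compound 2 by 3-chlorophenyl in place of 4-cyanophenyl on an amide-type nitrogen. Within the data shown here, no measured step touches the group on the amide-type nitrogen, so the one known step gives no direct guide to this change. For compound 3 a modest rise a 2.0-fold higher number from compound 2 to compound 3 (0.29 log units; within the scatter) is expected, with an estimate of 200 nM and a range from 60 nM to 700 nM.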

Compound 3, half-maximal inhibitory concentration: 42 nM
The estimate for compound 3 lay 4.8-fold (0.68 log units) above the measured number, and the stated range ends above it.
By their numbers in this assay, from the lowest: compounds 3, 1 and 2 (each within the scatter of the next, the first and the last beyond it).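

Among these compounds, on the amide-type nitrogen, 3-chlorophenyl in place of 4-cyanophenyl gives, in this assay, a 2.4-fold lower number from compound 2 to compound 3 (0.39 log units; beyond the scatter), so this position moves the number beyond the scatter, unlike the group on the triple-bonded carbon in the one earlier step. The change swaps nitrile for chlorine and alters the numbered place of the substituent, and this single pair cannot separate the two. Nothing on hand bears on the cause of this step.

As far as these compounds go, whether 4-chlorophenyl or 3-cyanophenyl would track the chlorine or the numbered place remains open. Unsubstituted phenyl would show what either substituent contributes.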